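The source may report more compounds than this note shows. Statements on the series, on what has been measured and on what is new or still open speak of the compounds shown alone.

Working notes on the shared core of compound 1 `O=C(Nc1cccc(Cl)c1)N[C@H]1CC[C@H](Oc2ccc(F)cc2)CC1`. In a functional assay on CRL2813 cells (Homo sapiens) for cytotoxicity, read by sulforhodamine B assay, with a stated time of 5 days (on this read-out higher numbers stand for weaker inhibition and lower numbers for stronger inhibition), compound 1 gives 5900 nM, the highest of the two numbers reported in this set. Compound 3 `O=C(Nc1cccc(C(F)(F)F)c1)N[C@H]1CC[C@H](Oc2ccc(OC(F)(F)F)cc2)CC1` gives 690 nM in this assay, a lower number by a gap beyond the usual scatter, so compound 1 is the weaker of the pair. Compound 2 `O=C(Nc1cccc(C(F)(F)F)c1)N[C@H]1CC[C@H](O)CC1` gives only a limit of the assay, > 20000 nM, and no number (the limit of > 20000 nM in this assay, at which 1 of the 3 values shown sits). Compound 4 `CSc1cccc(NC(=O)N[C@H]2CC[C@H](Oc3ccc(F)cc3)CC2)c1` remains to be measured. It differs from compound 1 in one place (methylsulfanyl in place of chloro on an aromatic carbon); the rest of the core is unchanged. No measured pair among the compounds shown carries this same change, so the size of the step rests on expectation alone. The step from compound 1 to compound 4 is expected to stay within the scatter, with no direction claimed beyond that a 1.2-fold lower number from compound 1 to compound 4 (0.07 log units; within the scatter). Compound 4 is accordingly estimated at 5000 nM in this assay, with a range from 2000 nM to 14000 nM.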

Compound 4, half-maximal inhibitory concentration: 11100 nM
Compound 4: the middle estimate sits 2.2-fold (0.35 log units) below what was measured; measured number inside the range.
By their numbers in this assay, from the lowest: compound 3; then compounds 1 and 4 (each within the scatter of the next). At a limit, above all of these: compound 2.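

In this assay, going by these compounds alone, methylsulfanyl in place of chloro on the aromatic carbon gives a 1.9-fold higher number from compound 1 to compound 4 (0.27 log units; within the scatter), the only single-place step in the set and the first reading at this position. At this place, meta to a large group, the exchange of 3-chlorophenyl for 3-(methylsulfanyl)phenyl therefore does not separate the two compounds in this assay, and neither group can be ranked over the other. Nothing shown here offers a reason for this step.

Still open, going by these compounds, is whether a different group at this position, such as an amine or a carboxylic acid, would shift the number beyond the scatter. Also open, on these data alone, is whether the same exchange reads alike on the core of compound 3.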